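Rearranging the Aryl Substituents on a Sulfonamide Nitrogen

The compounds below may be only part of what the source reports. "The series", "measured", "known", "first", "only" and "open" are said of these compounds alone.

Measured so far:
Compound 1, `O=C1NCCN1c1ccc(S(=O)(=O)Nc2ccc(C3CCCCC3)cc2)cc1`, in a functional assay on M21 cells (Homo sapiens) for antiproliferative activity, read by sulforhodamine B assay, with a stated time of 48 h (a higher number here means a weaker inhibitor, a lower number a stronger inhibitor), gives > 1000 nM, which is a limit of the assay rather than a number.
Compound 2, `CCCCc1ccc(NS(=O)(=O)c2ccc(N3CCNC3=O)cc2)cc1`, in this assay gives 450 nM.
Compound 3, `CCc1ccc(NS(=O)(=O)c2ccc(N3CCNC3=O)cc2)cc1`, in this assay gives 480 nM.

Of the two compounds with a number, compound 3 sits within the scatter of compound 2: a 1.1-fold higher number from compound 2 to compound 3 (0.03 log units; within the scatter). Compound 1 gives only a limit. From it the steps are an at least 2.2-fold lower number from compound 1 to compound 2 (0.34 log units; beyond the scatter) and an at least 2.0-fold lower number from compound 1 to compound 3 (0.31 log units; beyond the scatter), so a cyclohexyl at that place sets the weakest result shown, while butyl and ethyl behave alike.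

Compound 4, `Cc1ccc(C)c(NS(=O)(=O)c2ccc(N3CCNC3=O)cc2)c1`, has not yet been measured. It differs from compound 3 by 2,5-dimethylphenyl in place of 4-ethylphenyl on a sulfonamide nitrogen. Every measured step concerns the size of a single group on one aromatic carbon, not the placing of two methyl groups, so none speaks directly to this change. Going by the values given here, with no bearing step, the expected step of a 1.5-fold higher number from compound 3 to compound 4 (0.16 log units; within the scatter) is small and uncertain in direction. Compound 4 is therefore estimated at 700 nM, with a range from 300 nM to 2000 nM.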

Compound 4, half-maximal inhibitory concentration: 27 nM
Compound 4: the middle estimate sits 26-fold (1.41 log units) above what was measured; the whole stated range lies above it.
By their numbers in this assay, from the lowest: compound 4; then compounds 2 and 3 (each within the scatter of the next). At a limit, above all of these: compound 1.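

Earlier compounds changed only the size of one group on the aryl ring, and butyl and ethyl could not be told apart. Here the group on the sulfonamide nitrogen keeps the same heavy atoms and the same kind of ring, yet 2,5-dimethylphenyl in place of 4-ethylphenyl gives an 18-fold lower number from compound 3 to compound 4 (1.25 log units; beyond the scatter) in this assay, a large step. So at this place the arrangement of the carbons on the ring can matter far more than their number, although nothing measured here accounts for the size of this step.

The compounds shown do not tell whether both methyl groups are needed or whether a single methyl group would do as well. As far as these compounds go, it also stays open whether chlorine atoms or methoxy groups in place of the two methyl groups would hold the number in this range.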